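From 4-cyanophenoxy to 4-fluorophenyl in the series

This account rests on a few compounds, and the source may have more. Where it says the series, first, only, none or still open, it means among the compounds named here.

For the measured compounds named here, in an ADME assay on liver (Mesocricetus auratus) for metabolic stability, using microsomes (a lower number here means slower removal, a higher number faster removal of the compound), compound 2 `N#Cc1ccc(OC2CCN(C(=O)Nc3cc(-c4ccccn4)n[nH]3)CC2)cc1` gives 30.8 mL.min-1.g-1, the lower of the two numbers so far, while compound 1 `N#Cc1ccc(C2CCN(C(=O)Nc3cc(-c4ccccn4)n[nH]3)CC2)cc1` gives 80.8 mL.min-1.g-1. Compound 3 `O=C(Nc1cc(-c2ccccn2)n[nH]1)N1CCC(c2ccc(F)cc2)CC1` is not yet measured and carries 4-fluorophenyl in place of 4-cyanophenoxy on a saturated ring carbon. Going by the values given here, one measured step bears on this change: a 2.6-fold lower number from compound 1 to compound 2 (0.42 log units; beyond the scatter), modest and beyond the scatter, with 4-cyanophenoxy in place of 4-cyanophenyl. In compound 3, 4-fluorophenyl stands on the saturated ring carbon as 4-cyanophenyl does in compound 1. Among the compounds with values here, no measured step compares 4-cyanophenyl with 4-fluorophenyl, so the size remains uncertain. A higher number in this assay is expected, of about the size of the measured step reversed. The expected step is a 2.3-fold higher number from compound 2 to compound 3 (0.36 log units; beyond the scatter). The estimate for compound 3 is 70 mL.min-1.g-1, with an expected range from 35 mL.min-1.g-1 to 140 mL.min-1.g-1.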

Compound 3, intrinsic clearance in microsomes: 272 mL.min-1.g-1
Compound 3: middle estimate off by 3.9-fold (0.59 log units), on the low side, outside the stated range (above it).
By their numbers in this assay, from the lowest: compound 2; then compound 1; then compound 3.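

In this assay, for the compounds shown here, the group on the saturated ring carbon proves to have a wider effect than the earlier pair showed: 4-fluorophenyl in place of 4-cyanophenoxy gives an 8.8-fold higher number from compound 2 to compound 3 (0.95 log units; beyond the scatter), the largest step so far. Going by these compounds alone, the substituent on the aromatic ring also matters independently of the oxygen link, since fluoro in place of cyano on an aromatic carbon gives a 3.4-fold higher number from compound 1 to compound 3 (0.53 log units; beyond the scatter), a change the earlier compounds could not isolate. No accompanying measurement bears on why either number rises.

Still open, as far as these compounds go, is how the oxygen link and the ring substituent combine, and 4-fluorophenoxy on the same carbon would separate the two. Also open is where a methoxy group or a carboxylic acid in place of fluoro on the aromatic carbon would fall among these numbers.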